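A few compounds are considered here, and "the series" means these few. Any claim that something is new, unique, unknown or untested is made for them only; others in the source may bear on it.

Measured so far:
- compound 1 `CCCc1cc(OCC(=O)Nc2cc(C)cc(C)c2)c2cc(OC)ccc2n1` gives 12600 nM in a toxicity assay on HepG2 cells (Homo sapiens) for inhibition, read by CellTiter-Glo, with a stated time of 48 h; on this read-out lower numbers stand for stronger inhibition and higher numbers for weaker inhibition.
- compound 2 `COc1ccc2nc(C)cc(OCC(=O)Nc3cc(C)ccc3C)c2c1` gives > 100000 nM in this assay, which is a limit of the assay and not a number.

Compound 2 therefore stands at the limit of > 100000 nM in this assay, at which 1 of the 2 values shown sits; its true value is not pinned down beyond that. Within the data shown here, compound 1 is the only one of the pair with a numerical value, and no step between measured compounds is available, since compound 1 and compound 2 differ in more than one place.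

Compound 3 `COc1ccc2nc(C)cc(OCC(=O)Nc3ccc(Br)c(C)c3)c2c1` is to be measured in this assay. It differs from compound 2 by 4-bromo-3-methylphenyl in place of 2,5-dimethylphenyl on an amide-type nitrogen. Among the measured compounds shown here, with no measured step to lean on, the expectation rests on compound 2 alone, which sits at the limit. The exchange of 2,5-dimethylphenyl for 4-bromo-3-methylphenyl on the amide-type nitrogen is expected to give no step beyond the scatter, and a step of an at least 1.2-fold lower number from compound 2 to compound 3 (0.09 log units; that floor lies within the scatter) is the working estimate. Compound 3 is accordingly estimated at 80000 nM, with a range from 25000 nM to 250000 nM, and a fair chance that only a limit is reported again.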

Compound 3, half-maximal inhibitory concentration: 15900 nM
For compound 3 the middle estimate is 5.0-fold (0.70 log units) above the measured one; the whole stated range lies above it.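

In this assay, the aryl group on the amide-type nitrogen proves able to move the read-out: 4-bromo-3-methylphenyl in place of 2,5-dimethylphenyl gives an at least 6.2-fold lower number from compound 2 to compound 3 (0.79 log units; beyond the scatter). Among these compounds, this is the first change that can be read on its own, since the rest of the structure is shared, whereas compound 1 and compound 2 differ in more than one place and offer no such reading. The step has a floor but no measured size, because compound 2 carries a limit of the assay and not a number: the limit of > 100000 nM in this assay, at which 1 of the 3 values shown sits.

The exchange alters the aryl substitution as a whole, bringing in bromine while removing one methyl group, so the compounds shown cannot assign the step to either part of that change. Going by these compounds, how an unsubstituted phenyl, or a chlorine or an amine in place of the bromine, would read in this assay stays open, as does whether any aryl group on this nitrogen would carry the number further down.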